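Swapping fluorine for chlorine on the outer ring

A few compounds are considered here, and "the series" means these few. Any claim that something is new, unique, unknown or untested is made for them only; others in the source may bear on it.

Compound 1 `O=C(Nc1nc2ccc(Cl)cc2s1)c1cn(-c2ccccc2)nc1-c1ccc(F)cc1` gives 3170 nM in a functional assay on PC-3 cells (Homo sapiens) for cytotoxicity, read by MTT assay, with a stated time of 72 h; a lower number here means a stronger inhibitor, a higher number a weaker inhibitor.
Compound 2 `COc1ccc2nc(NC(=O)c3cn(-c4ccccc4)nc3-c3ccc(F)cc3)sc2c1` gives 12800 nM in this assay.
Compound 3 `Cc1ccc2nc(NC(=O)c3cn(-c4ccccc4)nc3-c3ccc(F)cc3)sc2c1` gives 20500 nM in this assay.

Among these three, compound 1 has the lowest number, so it is the strongest inhibitor of the set. The steps leading away from it are a 4.0-fold higher number from compound 1 to compound 2 (0.61 log units; beyond the scatter) and a 6.5-fold higher number from compound 1 to compound 3 (0.81 log units; beyond the scatter), both on the ring that carries chloro, methoxy or methyl; between the other two, a 1.6-fold higher number from compound 2 to compound 3 (0.20 log units; within the scatter) is too small to separate them.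

Compound 4 `O=C(Nc1nc2ccc(Cl)cc2s1)c1cn(-c2ccccc2)nc1-c1ccc(Cl)cc1` differs from compound 1 at the other end of the molecule: chloro in place of fluoro on an aromatic carbon. For the measured compounds named here, none of the measured steps touches this ring, so there is no direct precedent for the change; the measured steps speak only about the opposite ring, where chloro was the best of the three groups. With nothing pointing clearly either way, the expectation is a step no larger than the scatter of this assay, estimated as a 1.1-fold lower number from compound 1 to compound 4 (0.02 log units; within the scatter). Compound 4 is therefore estimated at 3000 nM, with a range from 1200 nM to 8000 nM.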

Compound 4, half-maximal inhibitory concentration: 3230 nM
Estimate against measurement, compound 4: 1.1-fold (0.03 log units) below; the range from low to high includes it.
By their numbers in this assay, from the lowest: compounds 1 and 4 (each within the scatter of the next); then compounds 2 and 3 (each within the scatter of the next).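

For the compounds shown here, the 4-fluorophenyl to 4-chlorophenyl change is the first measured step at this end of the molecule, and a 1.0-fold higher number from compound 1 to compound 4 (0.01 log units; within the scatter) shows that this assay does not tell these two halogens apart at this position. The earlier steps shown here all lay on the opposite ring, where a 4.0-fold higher number from compound 1 to compound 2 (0.61 log units; beyond the scatter) and a 6.5-fold higher number from compound 1 to compound 3 (0.81 log units; beyond the scatter) both stand beyond the usual scatter, so the two ends of the molecule have so far responded differently to the changes tried on them. No evidence at hand bears on this result.

Going by these compounds, whether an amine or a carboxylic acid at this position would leave the number equally unchanged remains open. So does whether methoxy or methyl on the opposite ring would give the same steps with the 4-chlorophenyl group in place.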